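Homologation of the hydroxymethyl group in compound 1

The compounds below may be only part of what the source reports. "The series", "measured", "known", "first", "only" and "open" are said of these compounds alone.

Compound 1 `C=CCc1cc(O)c(O)c(CN2CCC(CO)CC2)c1` is the starting point of this step. In a functional assay on MIA PaCa-2 cells (Homo sapiens) for inhibition, read by MTT assay, with a stated time of 72 h, tested at 50 uM (a lower number here means less inhibition of growth, a higher number more inhibition of growth at the concentration tested), compound 1 gives 38.6%. Among the three measured compounds this number sits in the middle. Compound 3 `C#CCOc1ccc(CC=C)cc1O` gives 30.3% in this assay, and the gap to compound 1 is within the usual scatter, so the two read as indistinguishable here. Compound 2 `C=CCc1ccc(OCc2cn(-c3cc(OC)c(OC)c(OC)c3)nn2)c(O)c1` gives 49.8% in this assay, a number that lies beyond the scatter above compound 1, and it is the only one of the three that stands apart from the others.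

Compound 4 `C=CCc1cc(O)c(O)c(CN2CCC(CCO)CC2)c1` has not been measured. Its difference from compound 1 is hydroxymethyl in place of hydroxy on a saturated chain carbon bound to a saturated ring carbon. The change keeps the same hydrogen-bond donor and acceptor count and adds one carbon to the side chain.

No step between two measured compounds that differ in one place is available, so there is no direct precedent for a change of this kind in this assay. Given that the change is small and the count of donors and acceptors is unchanged, the step from compound 1 to compound 4 is expected to be small, estimated at a number 1.4 percentage points higher from compound 1 to compound 4 (within the scatter), with no direction beyond the scatter.

Compound 4 is therefore expected to give about 40% in this assay, within a range from 28% to 52%.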

Compound 4, percent growth inhibition at one concentration: 71.8%
Compound 4: middle estimate off by 31.8 percentage points, on the low side; the whole stated range lies below it.
By their numbers in this assay, from the lowest: compounds 3 and 1 (each within the scatter of the next); then compound 2; then compound 4.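

In this assay, within the data shown here, the change from hydroxymethyl to 2-hydroxyethyl on the shared core gives a number 33.2 percentage points higher from compound 1 to compound 4 (beyond the scatter), the first step that isolates a single point of change. The position on the saturated ring is therefore sensitive to the length of the hydroxyl-bearing side chain, and the number moves well beyond the scatter even though the hydrogen-bond donor and acceptor counts under the change stay the same, so those counts alone do not set the growth inhibition at this position. Nothing at hand bears on what lies behind this step.

Open questions remain on both parts of the side chain: whether a longer chain such as 3-hydroxypropyl extends the step or reverses it, and whether the terminal hydroxy is needed at all, which an ethyl group, an amine or a carboxylic acid in its place on the same chain would test. Also open, from the compounds shown here alone, is whether the step depends on the rest of the core of compound 1, since this single pair gives no reading of the same change on any other scaffold.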